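Methyl in place of chloro on an aromatic carbon

The source may report more compounds than this note shows. Statements on the series, on what has been measured and on what is new or still open speak of the compounds shown alone.

Three compounds on one shared core have numbers in a functional assay on SW-620 cells (Homo sapiens) for cytotoxicity, read by sulforhodamine B assay, with a stated time of 48 h (a higher number here means a weaker inhibitor, a lower number a stronger inhibitor), so far. Compound 1 (`C[C@H]1CC[C@@H]2[C@@H](OC(=O)[C@]23CC(c2ccc(N(C)C)cc2)=NO3)[C@]2(C)C(=O)C=C[C@@]12O`) carries 4-(dimethylamino)phenyl and gives 5100 nM in this assay on that core. Compound 2 (`C[C@H]1CC[C@@H]2[C@@H](OC(=O)[C@]23CC(c2cccc([N+](=O)[O-])c2)=NO3)[C@]2(C)C(=O)C=C[C@@]12O`) carries 3-nitrophenyl and gives 49000 nM in the same test. Compound 3 (`C[C@H]1CC[C@@H]2[C@@H](OC(=O)[C@]23CC(c2ccccc2Cl)=NO3)[C@]2(C)C(=O)C=C[C@@]12O`) carries 2-chlorophenyl and gives 9000 nM in the same test. Compound 3 thus stands with compound 1 and apart from compound 2, with a 1.8-fold higher number from compound 1 to compound 3 (0.25 log units; within the scatter) on one side and a 5.4-fold lower number from compound 2 to compound 3 (0.74 log units; beyond the scatter) on the other.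

Compound 4 (`Cc1ccccc1C1=NO[C@]2(C1)C(=O)O[C@@H]1[C@H]2CC[C@H](C)[C@]2(O)C=CC(=O)[C@@]12C`) makes a single exchange on compound 3, namely methyl in place of chloro on an aromatic carbon in which methyl takes the place of chloro on an aromatic carbon, ortho to a large group. Going by the values given here, no measured step makes this exact exchange. The nearest evidence comes from replacing the whole aromatic group, which gave a 9.6-fold higher number from compound 1 to compound 2 (0.98 log units; beyond the scatter) in one case and a 1.8-fold higher number from compound 1 to compound 3 (0.25 log units; within the scatter) in another. Those steps change far more than this one does, and 2-methylphenyl stays close to 2-chlorophenyl in name and count. The estimated step is a 1.1-fold higher number from compound 3 to compound 4 (0.02 log units; within the scatter) in size, none beyond the scatter, with neither direction favoured. Compound 4 is expected at an estimated 9500 nM with a likely range from 4000 nM to 23000 nM in this test.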

Compound 4, half-maximal inhibitory concentration in the SW-620 assay: 5000 nM
Beside the measured number, compound 4's estimate is 1.9-fold (0.28 log units) above it; the measured number falls inside the stated range.
By their numbers in the SW-620 assay, from the lowest: compounds 4, 1 and 3 (each within the scatter of the next); then compound 2.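

Going by these compounds alone, in the SW-620 assay compound 4 gives 5000 nM, and the first reading confined to this one position, an aromatic carbon ortho to a large group, is a 1.8-fold lower number from compound 3 to compound 4 (0.26 log units; within the scatter), so chloro and methyl are not told apart here, whereas the earlier steps each replaced a whole aromatic group. The 2-methylphenyl group also stands level with 4-(dimethylamino)phenyl, at a 1.0-fold lower number from compound 1 to compound 4 (0.01 log units; within the scatter), and clearly apart from 3-nitrophenyl, at a 9.8-fold lower number from compound 2 to compound 4 (0.99 log units; beyond the scatter), which leaves 3-nitrophenyl as the only one of the four aromatic groups separated from the others. In a physicochemical assay for lipophilicity (a higher number here means a more lipophilic compound, a lower number a more polar compound), compound 3 gives 2.09 and compound 4 gives 1.86, and the same exchange gives a number 0.23 log units lower from compound 3 to compound 4 (within the scatter), so neither read-out separates this pair.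

Nothing available explains why the two groups read alike or why 3-nitrophenyl stands apart. The compounds shown leave open how a hydroxyl, a methoxy, an amine, a carboxylic acid or a longer chain would read at this same place, and whether chloro and methyl would still match elsewhere on the ring.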